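Methoxy added to the phenoxy ring of compound 2

This account rests on a few compounds, and the source may have more. Where it says the series, first, only, none or still open, it means among the compounds named here.

Compound 2 `COc1cccc(CNCCCNc2ccnc3cc(Oc4ccccc4)ccc23)c1O` gives 14500 nM in a physicochemical assay for solubility, with a stated time of 18 h, at pH 7.4 (a lower number here means a less soluble compound, a higher number a more soluble compound), level with compound 1 `c1ccc(Oc2ccc3c(NCCCNCc4ccco4)ccnc3c2)cc1`, which gives 14500 nM; the two are together the lowest of three numbers. Compound 3 `FC(F)(F)c1ccc(-c2ccc3c(NCCCNCc4ccco4)ccnc3c2)cc1` gives 32000 nM, which is a 2.2-fold higher number from compound 1 to compound 3 (0.34 log units; beyond the scatter). Compound 4 `COc1ccccc1Oc1ccc2c(NCCCNCc3cccc(OC)c3O)ccnc2c1` differs from compound 2 by methoxy in place of hydrogen on an aromatic carbon. Among the measured compounds shown here, no measured step makes this exact change. The nearest comparisons are a 2.2-fold higher number from compound 1 to compound 3 (0.34 log units; beyond the scatter), a change on an aromatic carbon, and no change at the digits printed from compound 1 to compound 2 (within the scatter), a change on the chain; one is modest, the other within scatter. For compound 4 a step at most at the edge of scatter in this assay is therefore expected, a 1.2-fold lower number from compound 2 to compound 4 (0.08 log units; within the scatter). Compound 4 is estimated at 12000 nM, in the range 5000 nM to 30000 nM.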

Compound 4, solubility: 14500 nM
The estimate for compound 4 lay 1.2-fold (0.08 log units) below the measured number, and the stated range covers the measured number.
By their numbers in this assay, from the lowest: compounds 1, 2 and 4 (each within the scatter of the next); then compound 3.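

In this assay, 2-methoxyphenoxy in place of phenoxy gives no change at the digits printed from compound 2 to compound 4 (within the scatter) and so shows that methoxy on this aromatic carbon, ortho to a large group, leaves the read-out level. This is the first step shown on the phenoxy ring itself; the earlier step on an aromatic carbon replaced the whole phenoxy group with 4-(trifluoromethyl)phenyl. No evidence is available that bears on this result. Open, as far as these compounds go, is whether an amine or a carboxylic acid at this place would move the number, and whether methoxy elsewhere on the ring would stay level too.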